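This account rests on a few compounds, and the source may have more. Where it says the series, first, only, none or still open, it means among the compounds named here.

Compound 1, with the structure `[N-]=[N+]=NCC(O)Cn1c(=O)n(C2OC(CO)[C@@H](O)[C@H]2O)c2nc(N)nc(O)c21`, carries a 2-azido-1-hydroxyethyl group on a saturated chain carbon bound to an aromatic nitrogen of the shared core. In a functional assay on the whole organism (B cells) with Mus musculus as the target (on this read-out higher numbers stand for larger maximal responses and lower numbers for smaller maximal responses), compound 1 gives 91%. Compound 2, `COc1ccc(Cn2c(=O)n(C3OC(CO)[C@@H](O)[C@H]3O)c3nc(N)nc(O)c32)cc1`, puts a 4-methoxyphenyl group in that place, and in this assay compound 2 gives 44%, a change of a number 47 percentage points lower from compound 1 to compound 2 (beyond the scatter). Compound 3, `N#Cc1cccc(Cn2c(=O)n(C3OC(CO)[C@@H](O)[C@H]3O)c3nc(N)nc(O)c32)c1`, carries a 3-cyanophenyl group in the same place and gives 16% in this assay, the lowest of the three numbers; the step of a number 75 percentage points lower from compound 1 to compound 3 (beyond the scatter) and the step of a number 28 percentage points lower from compound 2 to compound 3 (beyond the scatter) both lie beyond the scatter.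

Compound 4, `Nc1nc(O)c2c(n1)n(C1OC(CO)[C@@H](O)[C@H]1O)c(=O)n2Cc1ccc([N+](=O)[O-])cc1`, differs from compound 3 as follows: 4-nitrophenyl in place of 3-cyanophenyl on a saturated chain carbon bound to an aromatic nitrogen. For the measured compounds named here, only one measured step exchanges one aromatic group for another in this place, the step of a number 28 percentage points lower from compound 2 to compound 3 (beyond the scatter), which was modest; no step from a 3-cyanophenyl group to a 4-nitrophenyl group has been measured. Compound 3 already stands low, so the step is expected to be small, a number 4 percentage points higher from compound 3 to compound 4 (within the scatter), and compound 4 is expected to give 20% in this assay, in the range 5% to 45%.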

Compound 4, largest response reached (reported as maximal response), in percent of the reference or control that the assay uses: 147%
Compound 4: the middle estimate sits 127 percentage points below what was measured; the measured number lies above the stated range.
By their numbers in this assay, from the lowest: compound 3; then compound 2; then compound 1; then compound 4.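

The earlier compounds shown here placed both aromatic groups well below the 2-azido-1-hydroxyethyl group, but compound 4 goes against that pattern, with a number 56 percentage points higher from compound 1 to compound 4 (beyond the scatter) in this assay. For the compounds shown here, an aromatic group in this place is therefore not tied to a low number, and exchanging one for another can move the result far more widely than the earlier compounds showed, with a number 131 percentage points higher from compound 3 to compound 4 (beyond the scatter) and a number 103 percentage points higher from compound 2 to compound 4 (beyond the scatter). The last of these steps changes only methoxy to nitro on an aromatic carbon, so this single exchange on the ring is enough for a large rise, though no measurement shown gives a reason for it.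

Compound 3 and compound 4 differ both in the group on the ring and in its name-given place there, so these compounds do not separate the two changes. As far as these compounds go, whether an amine or a carboxylic acid in place of the nitro group would keep the number high also remains open.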